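The source may hold more compounds than are shown below. What is called first, only, known or untested is meant among the compounds shown, and "the series" means these compounds.

Compound 2 `CCCCOc1ccc2c(c1)/C(=N/N1CC(=O)N(CCCCN3CCN(C)CC3)C1=O)CCO2` stands at the lowest of the two numbers recorded so far in an assay on cells (Ventricular myocyte) for inhibition of potassium voltage-gated channel subfamily KQT member 1 (Cavia porcellus), read by patch clamp (on this read-out higher numbers stand for weaker inhibition and lower numbers for stronger inhibition), where compound 2 gives 22 nM. Its nearest neighbour is compound 1 `COc1ccc2c(c1)/C(=N/N1CC(=O)N(CCCCN3CCN(C)CC3)C1=O)CCO2`, which in this assay gives 650 nM. Within the data shown here, the only measured step, a 30-fold lower number from compound 1 to compound 2 (1.47 log units; beyond the scatter), came from propyl in place of hydrogen on a saturated chain carbon bound to an oxygen on an aromatic ring.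

Compound 3 `CN1CCN(CCCCN2C(=O)CN(/N=C3\CCOc4ccc(C(N)=O)cc43)C2=O)CC1` has not yet been measured in this assay. It differs from compound 2 by carbamoyl in place of butoxy on an aromatic carbon. Among the measured compounds shown here, no measured step covers a carbamoyl group on the shared core, so the only guide is the step between compound 1 and compound 2, which shows that lengthening the chain on the ring oxygen lowered the number strongly. Taking the butoxy away altogether and putting a carbamoyl in its place is therefore expected to move the number upward, broadly undoing that gain, though how far remains uncertain. Compound 3 is expected to give 900 nM in this assay, within 150 nM to 5000 nM, which would be a step of a 41-fold higher number from compound 2 to compound 3 (1.61 log units; beyond the scatter).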

Compound 3, half-maximal inhibitory concentration: 330 nM
For compound 3 the middle estimate is 2.7-fold (0.44 log units) above the measured one, within the range that was stated.
By their numbers in this assay, from the lowest: compound 2; then compounds 3 and 1 (each within the scatter of the next).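

In this assay, replacing butoxy with carbamoyl on this aromatic carbon gives a 15-fold higher number from compound 2 to compound 3 (1.18 log units; beyond the scatter) and so removes most of the strong inhibition seen with the longer group. Set against the methoxy group on the same carbon, carbamoyl gives a 2.0-fold lower number from compound 1 to compound 3 (0.29 log units; within the scatter) and cannot be told apart from it, even though carbamoyl brings a hydrogen-bond donor that methoxy lacks. Among the three groups at this place, only butoxy stands apart from the other two, and nothing available explains that difference.

The compounds shown leave open whether the number falls steadily as the chain on the ring oxygen grows, or whether an ethoxy group or a hexyloxy group would break that line. They also leave open whether a plain butyl chain without the oxygen would match butoxy on this carbon, and whether an amine, a carboxylic acid or a carbamoyl group carrying a butyl chain on its nitrogen would stay close to carbamoyl or move towards butoxy.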